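Swapping the hydroxyphenyl arm of a urea hydrazone

This account rests on a few compounds, and the source may have more. Where it says the series, first, only, none or still open, it means among the compounds named here.

Measured so far in a functional assay on U-87MG ATCC cells (Homo sapiens) for cytotoxicity, read by MTT assay, with a stated time of 72 h; a higher number here means a weaker inhibitor, a lower number a stronger inhibitor:
compound 1 `CN(C)CCn1cnnc1-c1cc(Oc2ccc(NC(=O)N/N=C/c3cccc(O)c3)cc2F)ccn1` gives > 100000 nM.
compound 2 `CN(C)CCn1cnnc1-c1cc(Oc2ccc(NC(=O)N/N=C/c3ccc(F)cc3Cl)cc2F)ccn1` gives 1210 nM.
compound 3 `CN(C)CCn1cnnc1-c1cc(Oc2ccc(NC(=O)N/N=C/c3c(O)ccc4ccccc34)cc2F)ccn1` gives 620 nM.

The result of compound 1 is only a limit of the assay, > 100000 nM, as recorded in the limit of > 100000 nM in this assay, at which 1 of the 3 values shown sits, so no number stands for it. Compound 2 and compound 3 share its core and differ only in the group on the carbon with a double bond to nitrogen, and both steps away from compound 1 are large: an at least 82-fold lower number from compound 1 to compound 2 (1.91 log units; beyond the scatter) and an at least 160-fold lower number from compound 1 to compound 3 (2.20 log units; beyond the scatter). Between them the gap is small, a 2.0-fold lower number from compound 2 to compound 3 (0.29 log units; within the scatter).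

Compound 4 `Cc1cc(/C=N/NC(=O)Nc2ccc(Oc3ccnc(-c4nncn4CCN(C)C)c3)c(F)c2)cc(C)c1O` is not yet measured. Against compound 1 the change is 4-hydroxy-3,5-dimethylphenyl in place of 3-hydroxyphenyl on a carbon with a double bond to nitrogen. The two measured steps from compound 1 both removed the 3-hydroxyphenyl and brought large falls in this assay, so they point downward here as well; yet neither replacement kept a hydroxyl on the ring, whereas the entering 4-hydroxy-3,5-dimethylphenyl does, so the expectation is weaker. Compound 4 is therefore expected to give about 20000 nM, between 2000 nM and 100000 nM. The step expected is an at least 5.0-fold lower number from compound 1 to compound 4 (0.69 log units; beyond the scatter).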

Compound 4, half-maximal inhibitory concentration: 7710 nM
Estimate against measurement, compound 4: 2.6-fold (0.41 log units) above, within the range that was stated.
By their numbers in this assay, from the lowest: compounds 3 and 2 (each within the scatter of the next); then compound 4. At a limit, above all of these: compound 1.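

In this assay, a single phenyl ring that carries a hydroxyl can give a measured number on the carbon with a double bond to nitrogen, with an at least 12-fold lower number from compound 1 to compound 4 (1.11 log units; beyond the scatter). Compound 1 remains only a limit of the assay: the limit of > 100000 nM in this assay, at which 1 of the 4 values shown sits. Replacements at this place also separate into distinct levels rather than a single drop, with a 6.4-fold higher number from compound 2 to compound 4 (0.80 log units; beyond the scatter) and a 12-fold higher number from compound 3 to compound 4 (1.09 log units; beyond the scatter).

Compound 4 differs from compound 1 both in its two methyl groups and in where the hydroxyl sits on the ring, and the compounds shown do not separate these two changes. Also open, going by these compounds, is how a phenyl ring carrying an amine or a carboxylic acid at this place would read in this assay.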